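Compound 4: 2-(piperazin-1-yl)ethyl in place of piperidin-3-yl

The source may report more compounds than this note shows. Statements on the series, on what has been measured and on what is new or still open speak of the compounds shown alone.

In an ADME assay on microsomes from liver (Mus musculus) for metabolic stability, read by LC-MS, with a stated time of 10 min, tested at 0.5 uM (on this read-out higher numbers stand for a more stable compound and lower numbers for a less stable compound), compound 3 `c1ccc2c(c1)CN[C@@H](CN(CC[C@H]1CCCNC1)[C@H]1CCCc3cccnc31)C2` stands highest of the three measured compounds, at 56%. Compound 1 `c1ccc2c(c1)CN[C@@H](CN(CC[C@@H]1CCCNC1)[C@H]1CCCc3cccnc31)C2` gives 23%, and compound 2 `c1ccc2c(c1)CN[C@@H](CN(CCCN1CCN(C3CC3)CC1)[C@H]1CCCc3cccnc31)C2` gives 3%. Compound 4 `c1ccc2c(c1)CN[C@@H](CN(CCCCN1CCNCC1)[C@H]1CCCc3cccnc31)C2` is still unmeasured. It carries 2-(piperazin-1-yl)ethyl in place of piperidin-3-yl on a saturated chain carbon, two bonds along the chain from an amine nitrogen.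

The most relevant evidence comes from two steps that also exchange piperidin-3-yl and a piperazine-bearing group. A large change appears in a number 53 percentage points higher from compound 2 to compound 3 (beyond the scatter), where the piperazine-bearing group gives way to piperidin-3-yl. A modest change appears in the opposite exchange, a number 20 percentage points lower from compound 1 to compound 2 (beyond the scatter). The two sizes differ, and the reason lies in the starting point: the large step of a number 33 percentage points higher from compound 1 to compound 3 (beyond the scatter) comes with the fact that compounds 1 and 3 differ only in the configuration as drawn. The level of compound 3 is therefore the higher of two values for piperidin-3-yl, and a fall from it should be the larger one.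

A large step to a lower number is expected, estimated as a number 36 percentage points lower from compound 3 to compound 4 (beyond the scatter). For compound 4 the expected value is 20%, with an estimated range from 5% to 45%.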

Compound 4, percent of the compound remaining: 96%
The estimate for compound 4 lay 76 percentage points below the measured number; the measured number lies above the stated range.
By their numbers in this assay, from the lowest: compound 2; then compound 1; then compound 3; then compound 4.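

In this assay, putting 2-(piperazin-1-yl)ethyl in place of piperidin-3-yl on a saturated chain carbon, two bonds along the chain from an amine nitrogen, raises the number from either piperidine compound, with a number 40 percentage points higher from compound 3 to compound 4 (beyond the scatter) and a number 73 percentage points higher from compound 1 to compound 4 (beyond the scatter). The only piperazine-bearing compound before this one stood lowest, yet a piperazine ring in the side chain does not by itself go with a low number here, as shown by a number 93 percentage points higher from compound 2 to compound 4 (beyond the scatter). The two steps from the piperidine compounds differ in size, and this is because they start from different levels: the fact that compounds 1 and 3 differ only in the configuration as drawn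

The step from compound 2 to compound 4 changes both the cyclopropyl group on the piperazine and the place of the ring along the chain, so the compounds shown do not separate these two changes. As far as these compounds go, it remains open whether a methyl group on the free piperazine nitrogen of compound 4 would keep the number high, and whether a morpholine ring in place of the piperazine on the same chain would do the same.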